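The source may hold more compounds than are shown below. What is called first, only, known or untested is meant among the compounds shown, and "the series" means these compounds.

Of the compounds shown here, two have so far been tested in a functional assay on MV4-11 cells (Homo sapiens) for inhibition, read by resazurin assay, with a stated time of 72 h; a higher number here means a weaker inhibitor of growth, a lower number a stronger inhibitor of growth. Compound 1 `COc1ccc(N(C)c2nccc(-c3cn(C)c4ccccc34)n2)c(OC)c1` gives 2000 nM in this assay, while compound 2 `COc1ccc(Nc2nccc(-c3sc(N(C)C)nc3C)n2)c(OC)c1` gives 170 nM, the lower of the two numbers, and the gap between them is beyond the usual scatter. Compound 3 `COc1ccc(Nc2nccc(-c3sc(OC)nc3C)n2)c(OC)c1` has not been measured; it differs from compound 2 in one place: methoxy in place of dimethylamino on an aromatic carbon. For the measured compounds named here, no measured pair shows this change, so the expectation rests on the change alone, and a modest weakening of growth inhibition is expected, a 2.9-fold higher number from compound 2 to compound 3 (0.47 log units; beyond the scatter). Compound 3 is estimated to give about 500 nM, within a range from 170 nM to 1500 nM.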

Compound 3, concentration for 50% growth inhibition: 1400 nM
Compound 3: the middle estimate sits 2.8-fold (0.45 log units) below what was measured, and the stated range covers the measured number.
By their numbers in this assay, from the lowest: compound 2; then compounds 3 and 1 (each within the scatter of the next).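

On the aromatic carbon next to the ring nitrogen and the ring sulfur, the choice of group clearly matters in this assay: methoxy in place of dimethylamino gives an 8.2-fold higher number from compound 2 to compound 3 (0.92 log units; beyond the scatter) and so weakens growth inhibition. The two groups have the same counts of hydrogen-bond donors and acceptors and no net charge, so those counts do not separate them. No available measurement gives a reason for the step. On these data alone, it remains open how a smaller amine such as methylamino, or a longer chain such as ethoxy, would behave at this carbon.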